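Lactam to Imidazole on the Side-Chain Carbon

The source may hold more compounds than are shown below. What is called first, only, known or untested is meant among the compounds shown, and "the series" means these compounds.

Of the compounds shown here, three sharing one core have been measured in an ADME assay on microsomes from liver (Mus musculus) for metabolic stability; a higher number here means that the compound lasts longer, a lower number that the compound disappears faster. Compound 1 `CC(C)C(c1nnc[nH]1)c1ccc(-c2ccc3cccc(F)c3c2)[nH]c1=O` gives 0.213 h. Compound 2 `CC(C)C(c1ccc(-c2ccc3cccc(F)c3c2)[nH]c1=O)N1CCCCC1=O` gives 0.0967 h. Compound 3 `CCn1ncc2c(F)cc(-c3ccc(C(CC)(CC)c4nnc(C)[nH]4)c(=O)[nH]3)cc21` gives only a limit of the assay, > 3 h. Among the numbers, compound 2 stands lowest of the two, with compound 1 as its nearest neighbour, the two being separated by the step of a 2.2-fold lower number from compound 1 to compound 2 (0.34 log units; beyond the scatter), in which 2-oxopiperidin-1-yl took the place of 4H-1,2,4-triazol-3-yl on a saturated chain carbon bound to an aromatic carbon and a saturated chain carbon.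

Compound 4 `Cc1nc(C(c2ccc(-c3ccc4cccc(F)c4c3)[nH]c2=O)C(C)C)[nH]c1C` has not yet been measured. It differs from compound 2 in one place: 4,5-dimethyl-1H-imidazol-2-yl in place of 2-oxopiperidin-1-yl on a saturated chain carbon bound to an aromatic carbon and a saturated chain carbon. Going by the values given here, the only measured step bearing on this change is the one from compound 1 to compound 2, where the lactam entered and an aromatic azole left; here an aromatic azole returns in place of the lactam. A modest rise of about that size is therefore expected, because the step of a 2.2-fold lower number from compound 1 to compound 2 (0.34 log units; beyond the scatter) ran the other way. Compound 4 is expected to give 0.2 h (from 0.08 h to 0.5 h). That estimate means an expected step of a 2.1-fold higher number from compound 2 to compound 4 (0.32 log units; beyond the scatter) in this assay.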

Compound 4, half-life: 0.0817 h
Compound 4: middle estimate off by 2.4-fold (0.39 log units), on the high side; low and high end bracket the measured number.
By their numbers in this assay, from the lowest: compounds 4 and 2 (each within the scatter of the next); then compound 1. At a limit, above all of these: compound 3.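

In this assay, the change reads as a 1.2-fold lower number from compound 2 to compound 4 (0.07 log units; within the scatter), so on this saturated chain carbon, putting an aromatic azole in place of the lactam does not by itself bring back the number of compound 1. The azoles are not interchangeable here, as the comparison gives a 2.6-fold lower number from compound 1 to compound 4 (0.42 log units; beyond the scatter), which leaves 4H-1,2,4-triazol-3-yl apart from both 4,5-dimethyl-1H-imidazol-2-yl and 2-oxopiperidin-1-yl. No measurement at hand says why these groups fall as they do.

As far as these compounds go, it remains open whether the methyl groups or the imidazole ring itself set this number, a question that a plain imidazole without methyl groups would help to separate. Also open, from the compounds shown here alone, is how an amine or a carboxylic acid on the same saturated chain carbon would read in this assay.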